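Bromo for chloro on the fused ring of compound 3

The source may hold more compounds than are shown below. What is called first, only, known or untested is meant among the compounds shown, and "the series" means these compounds.

Working notes on the series. Compound 1 `NC(=S)N/N=C1/C(=O)N(CN2CCN(c3ccnc4cc(Cl)ccc34)CC2)c2cccc(Cl)c21` is the reference point; in an ADME assay on 184B5 cells (Homo sapiens) for cytotoxicity, read by sulforhodamine B assay, with a stated time of 48 h (on this read-out higher numbers stand for weaker inhibition of growth and lower numbers for stronger inhibition of growth), compound 1 gives 20700 nM. Compound 2 `NC(=S)N/N=C1/C(=O)N(CN2CCN(c3ccnc4cc(Cl)ccc34)CC2)c2cccc(Br)c21` carries bromo in place of chloro on the aromatic carbon of the shared core; compound 2 gives 46400 nM, and the step is a 2.2-fold higher number from compound 1 to compound 2 (0.35 log units; beyond the scatter). Compound 3 `NC(=S)N/N=C1/C(=O)N(CN2CCN(c3ccnc4cc(C(F)(F)F)ccc34)CC2)c2cccc(Cl)c21` carries trifluoromethyl in place of chloro on the fused two-ring system; compound 3 gives 87800 nM, and the step is a 4.2-fold higher number from compound 1 to compound 3 (0.63 log units; beyond the scatter). Compound 3 thus stands highest of the three numbers: its gap to compound 2 lies within the scatter, its gap to compound 1 beyond it.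

Compound 4 `NC(=S)N/N=C1/C(=O)N(CN2CCN(c3ccnc4cc(C(F)(F)F)ccc34)CC2)c2cccc(Br)c21` differs from compound 3 by bromo in place of chloro on an aromatic carbon, on an aromatic carbon of a six-membered aromatic ring of carbon only, part of a fused or bridged system of two rings. Going by the values given here, the only measured step of this kind is a 2.2-fold higher number from compound 1 to compound 2 (0.35 log units; beyond the scatter), made in the chloro-bearing pair rather than the trifluoromethyl-bearing one; whether the shift carries over is untested. Taking that step as the guide, a modest upward step is expected, a 1.9-fold higher number from compound 3 to compound 4 (0.29 log units; within the scatter). Compound 4 is therefore estimated at 170000 nM, with a range from 80000 nM to 350000 nM. Since this sits at the top of the measured numbers, compound 4 may return only a limit.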

Compound 4, concentration for 50% growth inhibition: 26400 nM
Compound 4: middle estimate off by 6.4-fold (0.81 log units), on the high side; measured number below the stated range.
By their numbers in this assay, from the lowest: compounds 1, 4, 2 and 3 (each within the scatter of the next, the first and the last beyond it).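

With trifluoromethyl on the fused two-ring system, bromo in place of chloro in this assay gives a 3.3-fold lower number from compound 3 to compound 4 (0.52 log units; beyond the scatter), so at this place, on an aromatic carbon of a six-membered aromatic ring of carbon only, the direction of the change is not fixed but differs between the two cores: the same change on two cores in this assay, a 2.2-fold higher number (0.35 log units; beyond the scatter) from compound 1 to compound 2 and a 3.3-fold lower number (0.52 log units; beyond the scatter) from compound 3 to compound 4, 7.5-fold (0.87 log units) apart, beyond the scatter of two such steps. Read through the other place, trifluoromethyl in place of chloro gives a 1.8-fold lower number from compound 2 to compound 4 (0.24 log units; within the scatter) on the bromo-bearing core, a step that stays within the scatter and does not repeat the rise seen on the chloro-bearing core: the same change on two cores in this assay, a 4.2-fold higher number (0.63 log units; beyond the scatter) from compound 1 to compound 3 and a 1.8-fold lower number (0.24 log units; within the scatter) from compound 2 to compound 4, 7.5-fold (0.87 log units) apart, beyond the scatter of two such steps. The two places therefore do not behave as independent contributions across these four compounds, and a step measured on one core cannot be carried over to the other in this assay.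

On these data alone, it remains open whether fluoro, methoxy or an amine on this aromatic carbon would follow the chloro-bearing pair or the trifluoromethyl-bearing pair. As far as these compounds go, it also remains open whether a nitrile in place of trifluoromethyl on the fused two-ring system would show the same dependence on the group at the other place.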